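Swapping the aryl group on a shared core

This account rests on a few compounds, and the source may have more. Where it says the series, first, only, none or still open, it means among the compounds named here.

Three compounds share one core and differ only in the aryl group attached to it. In a functional assay on A549 cells (Homo sapiens) for antiproliferative activity, read by MTT assay, with a stated time of 72 h (a higher number here means a weaker inhibitor, a lower number a stronger inhibitor), compound 1 `COc1cc(-n2cnc3ccc(-c4ccc([N+](=O)[O-])cc4)cc32)cc(OC)c1OC` gives 8940 nM, compound 2 `COc1cc(-n2cnc3ccc(-c4ccc(C(F)(F)F)cc4)cc32)cc(OC)c1OC` gives 3390 nM, and compound 3 `COc1cccc(-c2ccc3ncn(-c4cc(OC)c(OC)c(OC)c4)c3c2)c1` gives 3180 nM. Compound 3 stands at the low end of the three numbers, though compound 2 sits within the scatter of it; only compound 1 lies beyond. The steps seen were a 2.6-fold lower number from compound 1 to compound 2 (0.42 log units; beyond the scatter), a 2.8-fold lower number from compound 1 to compound 3 (0.45 log units; beyond the scatter) and a 1.1-fold lower number from compound 2 to compound 3 (0.03 log units; within the scatter). Compound 4 `COc1cc(-n2cnc3ccc(-c4cc(F)ccc4F)cc32)cc(OC)c1OC` carries 2,5-difluorophenyl in place of 3-methoxyphenyl on an aromatic carbon. Since the aryl swaps seen so far moved this assay by modest amounts at most, another modest shift or none beyond the scatter is expected, an estimated 1.2-fold higher number from compound 3 to compound 4 (0.08 log units; within the scatter). Compound 4 is therefore estimated at 3800 nM, with a range from 1500 nM to 9500 nM.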

Compound 4, half-maximal inhibitory concentration: 7940 nM
Estimate against measurement, compound 4: 2.1-fold (0.32 log units) below, within the range that was stated.
By their numbers in this assay, from the lowest: compounds 3 and 2 (each within the scatter of the next); then compounds 4 and 1 (each within the scatter of the next).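

With a 2.5-fold higher number from compound 3 to compound 4 (0.40 log units; beyond the scatter) and a 2.3-fold higher number from compound 2 to compound 4 (0.37 log units; beyond the scatter), the 2,5-difluorophenyl group shows that the higher number at this position is not confined to the 4-nitrophenyl group, as a 1.1-fold lower number from compound 1 to compound 4 (0.05 log units; within the scatter) stays within the scatter. At this position, the aryl groups shown thus fall into two sets: 3-methoxyphenyl with 4-(trifluoromethyl)phenyl, and 2,5-difluorophenyl with 4-nitrophenyl. Nothing available explains this split.

Still open, as far as these compounds go, is how an aryl group bearing an amine or a carboxylic acid would read in this assay. Also open, from the compounds shown here alone, is whether a simple unsubstituted phenyl would fall with either set.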